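Extending an amine chain on a shared core

The compounds below may be only part of what the source reports. "The series", "measured", "known", "first", "only" and "open" are said of these compounds alone.

Three compounds built around closely related cores, each carrying a long chain that ends in amine groups, have been tested in a functional assay on DU-145 cells (Homo sapiens) for antiproliferative activity, read by MTT assay, with a stated time of 48 h; on this read-out lower numbers stand for stronger inhibition and higher numbers for weaker inhibition. Compound 1 `COc1ccc(/C=C/C(=O)c2cc(OC)c(OC)c(OC)c2)cc1OCCCC(=O)NCCCCN(CCCN)CCCCNCCCN` gives 84900 nM in this assay. Compound 2 `COc1cc(C(=O)/C=C/c2ccc(OCCCC(=O)NCCCCNCCCN)cc2)cc(OC)c1OC` gives 54800 nM. Compound 3 `COc1ccc(/C=C/C(=O)c2cc(OC)c(OC)c(OC)c2)cc1OCCCC(=O)NCCCCNCCCN` gives 99300 nM. All three numbers lie within the usual scatter of one another, so none of the three can be set above or below the others on this read-out.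

Compound 1 differs from compound 3 in one place: 4-((3-aminopropyl)amino)butyl in place of hydrogen on an amine nitrogen. That change gave a 1.2-fold lower number from compound 3 to compound 1 (0.07 log units; within the scatter). The cores of compound 2 and compound 3 also differ from each other, but the difference between the two cores is not broken down here.

Compound 4 `COc1cc(C(=O)/C=C/c2ccc(OCCCC(=O)NCCCCN(CCCN)CCCCNCCCN)cc2)cc(OC)c1OC` has not yet been measured. It differs from compound 2 by the same change made from compound 3 to compound 1: 4-((3-aminopropyl)amino)butyl in place of hydrogen on an amine nitrogen. The surroundings of the place are described in the same words in both cases, so the change is the same.

Because a 1.2-fold lower number from compound 3 to compound 1 (0.07 log units; within the scatter) stayed within the scatter, the step is expected to be similarly small, namely a 1.2-fold lower number from compound 2 to compound 4 (0.07 log units; within the scatter). The expectation rests on a single earlier example, so it carries little weight beyond that. Compound 4 is therefore expected to give 47000 nM, with a likely range from 22000 nM to 100000 nM.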

Compound 4, half-maximal inhibitory concentration: 92500 nM
For compound 4 the middle estimate is 2.0-fold (0.29 log units) below the measured one, within the range that was stated.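

On the core of compound 2, in this assay, placing 4-((3-aminopropyl)amino)butyl on the amine nitrogen gives a 1.7-fold higher number from compound 2 to compound 4 (0.23 log units; within the scatter), so on this core too the step is no larger than the normal spread of repeated measurements. Set beside the earlier step, the two results cannot be told apart, and the change can be said to carry over from one core to the other only in this limited sense: the same change on two cores in this assay, a 1.2-fold lower number (0.07 log units; within the scatter) from compound 3 to compound 1 and a 1.7-fold higher number (0.23 log units; within the scatter) from compound 2 to compound 4, 2.0-fold (0.30 log units) apart, within the scatter of two such steps. This shows that on both cores shown the added chain leaves the number within the scatter, and the opposite directions printed for the two steps should not be read as a real difference between the cores; it does not show that the change would behave the same way on any other core, and two pairs are too few to establish a rule for the series.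

The compounds shown leave open whether a chain ending in a carboxylic acid or a hydroxyl group instead of an amine would move the number beyond the scatter. They also leave open how a longer chain carrying a further amine would behave on either core.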